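Changing the aryl group on the shared core

The source may report more compounds than this note shows. Statements on the series, on what has been measured and on what is new or still open speak of the compounds shown alone.

Three compounds have been measured in an assay on membranes from liver for displacement of a labelled ligand from Glucagon receptor (Mus musculus), read by scintillation counting, with a stated time of 60 min; a higher number here means a weaker inhibitor, a lower number a stronger inhibitor:

Compound 1, `CC(C)(C)CC[C@H](c1ccc(C(=O)NCc2nn[nH]n2)cc1)N1C(=O)C(c2cncc(Cl)c2)=N[C@]12CC[C@@H](C(C)(C)C)CC2`, gives 84 nM.
Compound 2, `C[C@H](c1ccc(C(=O)NCCC(=O)O)cc1)N1C(=O)C(c2cccc(OC(F)(F)F)c2)=N[C@]12CC[C@@H](C(C)(C)C)CC2`, gives 1500 nM.
Compound 3, `CC1(CC[C@H](c2ccc(C(=O)NCc3nn[nH]n3)cc2)N2C(=O)C(c3cc(Cl)cc(Cl)c3)=N[C@]23CC[C@@H](C(C)(C)C)CC3)CC1`, gives 110 nM.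

Compound 2 stands at the highest number of the three, meaning it is the weakest inhibitor shown. The gap to compound 3, the nearest of the other two, lies beyond the usual scatter, and so does the larger gap to compound 1. For the measured compounds named here, compound 2 also differs from the other two in several places at once, so no single-change step among the measured compounds can be read from these data.

Compound 4, `C[C@H](c1ccc(C(=O)NCCC(=O)O)cc1)N1C(=O)C(c2ccc(F)cc2)=N[C@]12CC[C@@H](C(C)(C)C)CC2`, has not yet been measured. It differs from compound 2 in one place: 4-fluorophenyl in place of 3-(trifluoromethoxy)phenyl on a carbon with a double bond to nitrogen. The group that leaves carries one hydrogen-bond acceptor and the group that enters carries none.

Going by the values given here, no measured pair shows what such a change does on this core, so the expected step from compound 2 to compound 4 in this assay is a small one, a 1.7-fold higher number from compound 2 to compound 4 (0.22 log units; within the scatter), toward a slightly higher number or none beyond the scatter. Compound 4 is therefore expected to give about 2500 nM, with a plausible range from 800 nM to 8000 nM.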

Compound 4, half-maximal inhibitory concentration: 2500 nM
Compound 4: the middle estimate sits on the measured number at the digits printed; measured number inside the range.
By their numbers in this assay, from the lowest: compounds 1 and 3 (each within the scatter of the next); then compounds 2 and 4 (each within the scatter of the next).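

In this assay, putting 4-fluorophenyl in place of 3-(trifluoromethoxy)phenyl on the carbon with a double bond to nitrogen gives a 1.7-fold higher number from compound 2 to compound 4 (0.22 log units; within the scatter) and so leaves the two compounds indistinguishable in this measurement. For the compounds shown here, this is the only single-change step on the shared core so far, and it shows that this position can hold either aryl group, one with 11 heavy atoms and a hydrogen-bond acceptor, the other with 7 heavy atoms and none, without a difference beyond the scatter. No measured property of these groups is available to bear on this result.

From the compounds shown here alone, the step says nothing about a very different group at this place, such as a phenyl ring carrying an amine or a carboxylic acid, so the limits of what the position accepts remain open. Going by these compounds alone, compound 1 and compound 3 differ from compound 2 and compound 4 in several places at once, so no steps to them can be read, and it stays open whether the same aryl exchange would behave alike on those compounds.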